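Compound 2 to compound 3: 4-methylpiperazin-1-yl replaces pyrrolidin-1-yl

The source may hold more compounds than are shown below. What is called first, only, known or untested is meant among the compounds shown, and "the series" means these compounds.

In a functional assay on HepG2 cells (Homo sapiens) for antiproliferative activity, read by MTT assay, with a stated time of 48 h (on this read-out lower numbers stand for stronger inhibition and higher numbers for weaker inhibition), compound 2 (`O=C(CN1CCCC1)Nc1ccc2ncnc(Nc3ccc(Br)cc3)c2c1`) gives > 100000 nM, a limit of the assay and not a number. Compound 2 thus stands at the limit of > 100000 nM in this assay, at which 1 of the 2 values shown sits. Compound 3 (`CN1CCN(CC(=O)Nc2ccc3ncnc(Nc4ccc(Br)cc4)c3c2)CC1`) has 4-methylpiperazin-1-yl in place of pyrrolidin-1-yl on a saturated chain carbon bound to a carbonyl carbon. Within the data shown here, compound 1 (`CN1CCN(CC(=O)Nc2ccc3ncnc(Nc4cccc(Br)c4)c3c2)CC1`) also carries 4-methylpiperazin-1-yl and gives 25300 nM in this assay, the only number available, so a modest strengthening beyond the scatter is expected. The expected change is an at least 2.0-fold lower number from compound 2 to compound 3 (0.30 log units; that floor lies within the scatter), and a second limit remains possible. For compound 3 the estimated value is 50000 nM, with an expected range of 20000 nM to 100000 nM.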

Compound 3, half-maximal inhibitory concentration: > 100000 nM
Compound 3 was reported as a limit (the forecaster's own chance of this, stated with the estimate: 35%); at least 2.0-fold (0.30 log units) between middle value and limit.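

In this assay the change from pyrrolidin-1-yl to 4-methylpiperazin-1-yl cannot be read, as the values of compound 2 and compound 3 are both limits of the assay and not numbers. What is new concerns the bromophenyl group: with 4-methylpiperazin-1-yl kept, 4-bromophenyl in place of 3-bromophenyl on a nitrogen on an aromatic ring gives an at least 3.9-fold higher number from compound 1 to compound 3 (0.59 log units; beyond the scatter). Both 4-bromophenyl compounds, compound 2 and compound 3, share one limit: the limit of > 100000 nM in this assay, at which 2 of the 3 values shown sit.

As far as these compounds go, whether the two cyclic amines differ at all remains open. Also open, from the compounds shown here alone, is how 3-chlorophenyl on that nitrogen, or morpholin-4-yl on the chain carbon, would read.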